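Compound 2 to compound 4: changing the carbonyl substituent

The source may hold more compounds than are shown below. What is called first, only, known or untested is meant among the compounds shown, and "the series" means these compounds.

In a functional assay on HeLa cells (Homo sapiens) for antiproliferative activity, read by MTT assay, with a stated time of 48 h (a lower number here means a stronger inhibitor, a higher number a weaker inhibitor), compound 2 (`COc1ccc(-c2cn3cc(C4=CCN(C(=O)c5ccc(Cl)cc5)CC4)ccc3n2)cc1OC`) gives 12200 nM, compound 1 (`COc1ccc(-c2cn3cc(C4=CCN(C(=O)C5CCCCC5)CC4)ccc3n2)cc1OC`) gives 8060 nM and compound 3 (`COc1ccc(-c2cn3cc(C4=CCN(C(=O)C(C)(C)C)CC4)ccc3n2)cc1OC`) gives 5480 nM. The steps reaching that first value are a 1.5-fold higher number from compound 1 to compound 2 (0.18 log units; within the scatter) and a 2.2-fold lower number from compound 2 to compound 3 (0.35 log units; beyond the scatter). Compound 4 (`COc1ccc(-c2cn3cc(C4=CCN(C(=O)c5cccs5)CC4)ccc3n2)cc1OC`) differs from it by thiophen-2-yl in place of 4-chlorophenyl on a carbonyl carbon. All measured steps change this same group, and the third is a 1.5-fold lower number from compound 1 to compound 3 (0.17 log units; within the scatter). None exchanges one aromatic ring for another, and the largest is modest. The expected change in this assay is therefore a 1.4-fold lower number from compound 2 to compound 4 (0.16 log units; within the scatter), with no step beyond the scatter expected. Compound 4 is estimated at 8500 nM, with an expected range of 4300 nM to 17000 nM.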

Compound 4, half-maximal inhibitory concentration: 16000 nM
Estimate against measurement, compound 4: 1.9-fold (0.27 log units) below; low and high end bracket the measured number.
By their numbers in this assay, from the lowest: compounds 3, 1, 2 and 4 (each within the scatter of the next, the first and the last beyond it).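

The exchange of one aromatic ring for another on this carbonyl carbon, thiophen-2-yl for 4-chlorophenyl, is now measured in this assay and stays within the scatter (a 1.3-fold higher number from compound 2 to compound 4 (0.12 log units; within the scatter)). Against the non-aromatic groups the thiophen-2-yl amide splits: the cyclohexyl pair also stays within the scatter (a 2.0-fold higher number from compound 1 to compound 4 (0.30 log units; within the scatter)), while the tert-butyl pair gives the largest step so far (a 2.9-fold higher number from compound 3 to compound 4 (0.47 log units; beyond the scatter)). No measurement shown gives a reason for these steps.

Open, from the compounds shown here alone, is whether an amine or a carboxylic acid on the carbonyl substituent, or a longer chain, would shift the number beyond this modest range.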